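Fluorinated benzyl replacement on a quinazoline-type pyrazolylamine scaffold

A few compounds are considered here, and "the series" means these few. Any claim that something is new, unique, unknown or untested is made for them only; others in the source may bear on it.

Compounds with measured values:
Compound 1, `Cc1ccc(CNc2nc(Nc3cc(C)[nH]n3)c3ccccc3n2)cc1`: 110 nM
Compound 2, `Cc1cc(Nc2nc(NCc3ccc(C(F)(F)F)cc3)nc3ccccc23)n[nH]1`: 1400 nM

In an assay for inhibition of high affinity nerve growth factor receptor (Homo sapiens), read by HTRF, with a stated time of 30 min, in the presence of a further agent that is not named here (a higher number here means a weaker inhibitor, a lower number a stronger inhibitor), compound 1 gives 110 nM, the lowest of the two numbers recorded; the nearest is compound 2, which gives 1400 nM. For the measured compounds named here, the one step between measured compounds that differ in a single place is a 13-fold higher number from compound 1 to compound 2 (1.10 log units; beyond the scatter), with trifluoromethyl in place of methyl on an aromatic carbon.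

Compound 3, `Cc1cc(Nc2nc(NCc3cc(F)c(F)c(F)c3)nc3ccccc23)n[nH]1`, is not yet measured in this assay. It differs from compound 1 as follows: 3,4,5-trifluorophenyl in place of 4-methylphenyl on a saturated chain carbon bound to a nitrogen on an aromatic ring. Going by the values given here, the only measured step that bears on this change is the one from compound 1 to compound 2, where the substituent on the benzyl ring was altered and the number rose far beyond the scatter. Compound 3 also alters that ring, though with three fluorines rather than a trifluoromethyl group, so the change is not the same and the size of the effect is uncertain. A weakening is expected for compound 3, estimated as a 5.5-fold higher number from compound 1 to compound 3 (0.74 log units; beyond the scatter), because the related step of a 13-fold higher number from compound 1 to compound 2 (1.10 log units; beyond the scatter) was large. Compound 3 is therefore expected to give about 600 nM, within a range of 200 nM to 2000 nM.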

Compound 3, half-maximal inhibitory concentration: 870 nM
Compound 3: middle estimate off by 1.5-fold (0.16 log units), on the low side, within the range that was stated.
By their numbers in this assay, from the lowest: compound 1; then compounds 3 and 2 (each within the scatter of the next).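

In this assay the replacement of 4-methylphenyl by 3,4,5-trifluorophenyl gives a 7.9-fold higher number from compound 1 to compound 3 (0.90 log units; beyond the scatter), so the rise in the number at this position is not confined to the trifluoromethyl group of the earlier comparison: it also appears when three fluorines sit on the ring and the methyl is gone. Compound 3 at 870 nM and compound 2 at 1400 nM lie within the scatter of each other, so these two fluorinated rings cannot be told apart here, and both stand beyond the scatter from compound 1, the earlier step being a 13-fold higher number from compound 1 to compound 2 (1.10 log units; beyond the scatter) for comparison. Nothing available accounts for either step.

The compounds shown leave open how much of each step follows from losing the methyl and how much from adding fluorine, a question that a plain phenyl on the same saturated chain carbon would help to separate. Also open, as far as these compounds go, is whether a 4-chlorophenyl, a 4-methoxyphenyl or a phenyl carrying an amine would stay close to compound 1 at 110 nM or rise as the fluorinated rings do.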